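The compounds below may be only part of what the source reports. "The series", "measured", "known", "first", "only" and "open" are said of these compounds alone.

Going by the values given here, in an ADME assay for permeability, using PAMPA, at pH 7.4 (a lower number here means that the compound crosses the layer more slowly, a higher number that the compound crosses the layer faster), compound 1 (`O=C(N[C@H]1CC[C@@H](c2ccccc2)CC1)c1[nH]c(=O)[nH]c(=O)c1O`) gives 12 nm/s and provides the only number so far. Compound 2 (`CC(C)Cn1c(=O)[nH]c(C(=O)N[C@H]2CC[C@@H](c3ccccc3)CC2)c(O)c1=O`) carries an isobutyl group, and its entry in this assay reads "not determined" (no result reported) with no place on the scale, so it offers no starting value. Compound 3 (`O=C(N[C@H]1CC[C@@H](c2ccccc2)CC1)c1[nH]c(=O)n(Cc2ccccc2)c(=O)c1O`) has not yet been measured. The structural change is phenyl in place of isopropyl on a saturated chain carbon bound to an aromatic nitrogen with phenyl in place of isopropyl on a saturated chain carbon bound to an aromatic nitrogen, which also reads as isobutyl to benzyl. Among the compounds with values here, no measured pair shows what such a change does here, so the expectation is no step beyond the usual scatter in this assay in either direction. With compound 1 at 12 nm/s as the sole anchor, the range must stay wide. For compound 3 the estimated reading is 20 nm/s with 4 nm/s to 100 nm/s as the expected range.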

Compound 3, apparent permeability: 158 nm/s
Compound 3: middle estimate off by 7.9-fold (0.90 log units), on the low side, and the stated range ends below it.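

Going by these compounds alone, compound 3 supplies the first measured pair in this set: in this assay, benzyl in place of hydrogen on an aromatic nitrogen goes with a 13-fold higher number from compound 1 to compound 3 (1.12 log units; beyond the scatter) and lies beyond the scatter of repeated measurements. The read-out is therefore not set by the shared core alone, and it can shift strongly with what sits on this nitrogen. Nothing measured here speaks to why the number rises.

On these data alone, compound 2 has no number on this scale, so the step from isobutyl to benzyl cannot be read, and it remains open whether benzyl stands apart from a plain carbon chain at this place. This single pair also gives no guide to how a longer chain, an amine or a carboxylic acid on the same nitrogen would read.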